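This account rests on a few compounds, and the source may have more. Where it says the series, first, only, none or still open, it means among the compounds named here.

In an assay on BT-474 cells for inhibition of disintegrin and metalloproteinase domain-containing protein 10 (Homo sapiens) (on this read-out lower numbers stand for stronger inhibition and higher numbers for weaker inhibition), compound 1 `O=C(NO)[C@H]1CC2(CC2)CN[C@@H]1C(=O)N1CCN(c2cccc(Cl)c2)CC1` gives 42 nM, whereas compound 2 `COC(=O)N1CC2(CC2)C[C@H](C(=O)NO)[C@H]1C(=O)N1CCC(c2ccccc2)CC1` gives 169 nM, the higher of the two numbers and a gap beyond the usual scatter. Compound 3 `O=C(NO)[C@H]1CC2(CC2)CN[C@@H]1C(=O)N1CCC(c2ccccc2)CC1` is not yet measured. It differs from compound 2 by hydrogen in place of methoxycarbonyl on an amine nitrogen in a ring. Going by the values given here, no two measured compounds differ only in that place, so the size of the step is not known from a direct comparison. Since compound 1, which also carries the free amine, gives 42 nM, a step toward a lower number is expected, estimated as a 2.8-fold lower number from compound 2 to compound 3 (0.45 log units; beyond the scatter). Compound 3 is expected to reach 60 nM, within 20 nM to 200 nM.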

Compound 3, half-maximal inhibitory concentration: 137 nM
Beside the measured number, compound 3's estimate is 2.3-fold (0.36 log units) below it; the measured number falls inside the stated range.
By their numbers in this assay, from the lowest: compound 1; then compounds 3 and 2 (each within the scatter of the next).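

In this assay, going by these compounds alone, the first direct reading at this amine nitrogen in a ring is a 1.2-fold lower number from compound 2 to compound 3 (0.09 log units; within the scatter) and so does not separate the two compounds. On the phenyl-bearing core shared by compound 2 and compound 3, methoxycarbonyl and hydrogen at this position therefore read alike in this assay. No measurement offered here explains this result. On these data alone, whether an acetyl group, a methyl group or a longer chain on the same nitrogen would read differently remains open, as does whether hydrogen and methoxycarbonyl would also read alike on the core of compound 1.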